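This account rests on a few compounds, and the source may have more. Where it says the series, first, only, none or still open, it means among the compounds named here.

Of the compounds shown here, three of a shared core have been tested in a functional assay for inhibition, with Homo sapiens as the target; a higher number here means a weaker inhibitor, a lower number a stronger inhibitor. Compound 1, `CCCc1ncc2cnnc(S)n12`, carries a propyl group and a thiol; in this assay compound 1 reaches only the assay limit, > 48000 nM, so no number is known for it. Compound 2, `C=CCSc1nncc2cnc(COC)n12`, gives 79000 nM in this assay. Compound 3, `C=CCSc1nncc2cnc(C)n12`, gives 61000 nM in this assay. Of the two numbers available, the value of compound 3 sits within the usual scatter of that of compound 2, so the two cannot be told apart; the third result is a limit, (the limit of > 48000 nM in this assay, at which 1 of the 3 values shown sits).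

Among the compounds with values here, the one measured step, a 1.3-fold lower number from compound 2 to compound 3 (0.11 log units; within the scatter), was a change of hydrogen in place of methoxy on a saturated chain carbon bound to an aromatic carbon, and it stayed within the scatter.

Compound 4, `C=CCSc1nncc2cnc(CCC)n12`, is not yet measured. It differs from compound 3 in this way: ethyl in place of hydrogen on a saturated chain carbon bound to an aromatic carbon. This change sits at the same saturated chain carbon that was altered between compound 2 and compound 3, where the measured step was too small to count. Because a 1.3-fold lower number from compound 2 to compound 3 (0.11 log units; within the scatter) showed no movement beyond the scatter, a step of about the same size is expected here, a 1.1-fold lower number from compound 3 to compound 4 (0.02 log units; within the scatter). Compound 4 is therefore estimated at 58000 nM, with a range from 25000 nM to 130000 nM, in this assay.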

Compound 4, half-maximal inhibitory concentration: > 48000 nM
Compound 4 gave a limit, no number (the forecaster's own chance of this, stated with the estimate: 30%); the middle value does not contradict the limit.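

Compound 4 gives only a limit in this assay, not a number, so its steps from compound 1, compound 2 and compound 3 cannot be read: the limit of > 48000 nM in this assay, at which 2 of the 4 values shown sit.

Still open, on these data alone, is whether ethyl in place of hydrogen on a saturated chain carbon bound to an aromatic carbon changes the inhibition at all.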